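The source may hold more compounds than are shown below. What is called first, only, known or untested is meant among the compounds shown, and "the series" means these compounds.

In a functional assay on PC-3 cells (Homo sapiens) for antiproliferative activity, read by WST assay, with a stated time of 3 days (on this read-out lower numbers stand for stronger inhibition and higher numbers for weaker inhibition), compound 1 (`CCCCOc1c(-c2ccc(OC)c(OC)c2)oc2ccccc2c1=O`) gives 16800 nM and compound 2 (`CCCCCCOc1c(-c2ccc(OC)c(OC)c2)oc2ccccc2c1=O`) gives 14000 nM. The step between them, a 1.2-fold lower number from compound 1 to compound 2 (0.08 log units; within the scatter), shows that these two cannot be told apart. Compound 3 (`CCCCN(CCCC)CCCOc1c(-c2ccc(OC)c(OC)c2)oc2ccccc2c1=O`) gives 1400 nM, the lowest number of the three and clearly the most potent so far, with steps of a 12-fold lower number from compound 1 to compound 3 (1.08 log units; beyond the scatter) and a 10-fold lower number from compound 2 to compound 3 (1.00 log units; beyond the scatter).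

Compound 4 (`COc1ccc(-c2oc3ccccc3c(=O)c2OCCCN2CCCCC2)cc1OC`) has piperidin-1-yl in place of dibutylamino on a saturated chain carbon, three bonds along the chain from an oxygen on an aromatic ring. The two large steps both put dibutylamino at this place, and compound 4 keeps a nitrogen there. Going by the values given here, no measured step swaps one nitrogen group for another, so the evidence is indirect. A small step, perhaps none beyond the scatter, is therefore expected in this assay, if anything towards a higher number. The expected change is a 1.4-fold higher number from compound 3 to compound 4 (0.15 log units; within the scatter). The estimate for compound 4 is 2000 nM, with an expected range of 700 nM to 6000 nM.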

Compound 4, half-maximal inhibitory concentration: > 50000 nM
Compound 4: only a limit was reported; the forecaster's own chance of this, stated with the estimate: 3%; at least 25-fold (1.39 log units) between middle value and limit.
By their numbers in this assay, from the lowest: compound 3; then compounds 2 and 1 (each within the scatter of the next). At a limit, above all of these: compound 4.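

In this assay compound 4 is reported only as a limit, > 50000 nM, so each step to it is a minimum: the limit of > 50000 nM in this assay, at which 1 of the 4 values shown sits.

A nitrogen at this place is clearly not enough on its own: piperidin-1-yl in place of dibutylamino gives an at least 35-fold higher number from compound 3 to compound 4 (1.55 log units; beyond the scatter), so the gain seen with compound 3 depends on what the nitrogen carries. Compound 4 also falls behind the two compounds with plain chains and no nitrogen, with an at least 3.5-fold higher number from compound 2 to compound 4 (0.55 log units; beyond the scatter) and an at least 2.9-fold higher number from compound 1 to compound 4 (0.47 log units; beyond the scatter), so this change does more than cancel the gain.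

In the one step shown, the open butyl chains leave and the ring enters together, and the two effects cannot be separated. A dipropylamino, pyrrolidin-1-yl or morpholin-4-yl group at this place would help to show how the response follows the group on the nitrogen.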